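The source may hold more compounds than are shown below. What is called first, only, known or untested is meant among the compounds shown, and "the series" means these compounds.

Compound 2 `CCCCCCCCCCCCCCCC1=C(C)C(=O)C(OC)=C(OC)C1=O` is the stronger of the two measured compounds: in a functional assay on CCRF-CEM cells (Homo sapiens) for cytotoxicity, read by trypan blue exclusion, with stated times of 17 h and 6 h, tested at 0.1 uM (on this read-out lower numbers stand for a weaker effect and higher numbers for a stronger effect at the one concentration tested), compound 2 gives 82%, whereas compound 1 `COC1=C(OC)C(=O)C(CCCCCCCCCCN=[N+]=[N-])=C(C)C1=O` gives 11%. Going by the values given here, the single measured step, a number 71 percentage points higher from compound 1 to compound 2 (beyond the scatter), shows that what sits at the far end of the long chain can move the read-out a great deal. Compound 3 `COC1=C(OC)C(=O)C(CCCCCCCCC(C)(C)C)=C(C)C1=O` differs from compound 2 in exactly that region, (tert-butyl in place of heptyl on a saturated chain carbon, eight bonds along the chain from a double-bonded ring carbon). The step from compound 1 to compound 2 bears on it only loosely, as it exchanged a heteroatom-bearing end for a carbon one, while here one carbon group is replaced by a shorter, branched carbon group. Since the chain is shortened, some loss is expected, but not a collapse to the level of compound 1. Compound 3 is therefore estimated at 60%, between 35% and 85%, which would mean an expected step of a number 22 percentage points lower from compound 2 to compound 3 (beyond the scatter).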

Compound 3, a percentage reported as activity, at one concentration (the size of the read-out at that concentration, not a potency): 9%
Compound 3: the middle estimate sits 51 percentage points above what was measured; measured number outside the range, below it.
By their numbers in this assay, from the lowest: compounds 3 and 1 (each within the scatter of the next); then compound 2.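

The chain end proves far more sensitive in this assay than the earlier step could show: tert-butyl in place of heptyl, on a saturated chain carbon eight bonds along the chain from a double-bonded ring carbon, gives a number 73 percentage points lower from compound 2 to compound 3 (beyond the scatter), so an exchange of one carbon group for another can have a large effect. Tert-butyl in place of 2-azidoethyl gives a number 2 percentage points lower from compound 1 to compound 3 (within the scatter), so these two chain ends cannot be told apart here, and the low level does not depend on an azido end. Nothing available explains the size of this change.

In compound 3 the chain is both shortened and branched, and the compounds shown do not separate the two changes. Going by these compounds, an unbranched chain of similar length, a longer chain, and an amine or a carboxylic acid at the chain end remain open.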